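Swapping the aryl on a thioether linker in a quinoxaline series

The compounds below may be only part of what the source reports. "The series", "measured", "known", "first", "only" and "open" are said of these compounds alone.

Measured compounds in a functional assay on OVCAR-8 cells (Homo sapiens) for inhibition, read by sulforhodamine B assay, with a stated time of 48 h; a lower number here means a stronger inhibitor of growth, a higher number a weaker inhibitor of growth:
- compound 1 `Nc1cc(N)c2nc(-c3ccccc3)c(NCc3ccc(F)cc3)nc2c1`: 2630 nM
- compound 2 `COc1ccc(Sc2nc3cc(N)cc(N)c3nc2-c2ccccc2)cc1`: < 100000 nM

For compound 2 the value in this assay is a limit, not a number, as the line the limit of < 100000 nM in this assay, at which 1 of the 2 values shown sits, records. This leaves compound 2 without a fixed place on the scale, and the step from compound 1, a step that the limit leaves unreadable from compound 1 to compound 2, cannot be sized either.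

Compound 3 `Nc1cc(N)c2nc(-c3ccccc3)c(Sc3ccc(Cl)c(Cl)c3)nc2c1` keeps the sulfur linker of compound 2 and changes only the ring attached to it: 3,4-dichlorophenyl in place of 4-methoxyphenyl on a sulfur. Within the data shown here, no measured step bears on this change. Among the measured compounds shown here, the one step available, from compound 1 to compound 2, alters the whole linker at once and reads only as a limit, so it says nothing about exchanging one aryl group for another on the sulfur. With nothing to lean on, no direction in this assay is expected beyond the scatter, and the estimate is deliberately wide. Compound 3 is expected to give about 10000 nM, between 1000 nM and 100000 nM, a step that the limit leaves unreadable from compound 2 to compound 3 from compound 2.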

Compound 3, concentration for 50% growth inhibition: 24500 nM
Compound 3: the middle estimate sits 2.5-fold (0.39 log units) below what was measured, and the stated range covers the measured number.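

In this assay, among these compounds, a sulfur-linked aryl group on this aromatic carbon now has a readable number for the first time, and putting (3,4-dichlorophenyl)sulfanyl in place of (4-fluorobenzyl)amino gives a 9.3-fold higher number from compound 1 to compound 3 (0.97 log units; beyond the scatter). On this shared core, then, the sulfur-linked compound is the weaker inhibitor of growth of the pair, by a margin beyond the usual scatter, although this one step changes the linker and the ring together. The exchange of 4-methoxyphenyl for 3,4-dichlorophenyl on the sulfur still cannot be read, and neither can the step from the amino-linked compound to the 4-methoxyphenyl thioether, since compound 2 has only a limit and not a number: the limit of < 100000 nM in this assay, at which 1 of the 3 values shown sits.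

It remains open whether the sulfur or the ring attached to it accounts for the weaker growth inhibition, as no pair shown separates the two. A (4-fluorobenzyl)sulfanyl group on this carbon would pull them apart, and how a morpholine or a carboxylic acid on the aryl ring would read in this assay is also unknown.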